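This account rests on a few compounds, and the source may have more. Where it says the series, first, only, none or still open, it means among the compounds named here.

Measured in an ADME assay on microsomes from liver (Rattus norvegicus) for metabolic stability, read by LC-MS, using NADPH, at 37 degrees C; on this read-out higher numbers stand for a longer-lived compound and lower numbers for a shorter-lived compound:
- compound 1 `Cc1ccc(C)c(-c2nc(CN3CCC(C(=O)NCCCN4C[C@H](C)C[C@H](C)C4)CC3)c(C)o2)c1`: 0.5 h
- compound 2 `Cc1cccc(F)c1-c1nc(CN2CCC(C(=O)NCCCN3C[C@H](C)C[C@H](C)C3)CC2)c(C)o1`: 0.0733 h

Compound 2 is the lower of the two, at 0.0733 h. Compound 3 `COc1cccc(Br)c1-c1nc(CN2CCC(C(=O)NCCCN3C[C@H](C)C[C@H](C)C3)CC2)c(C)o1` differs from it by 2-bromo-6-methoxyphenyl in place of 2-fluoro-6-methylphenyl on an aromatic carbon, with 2-bromo-6-methoxyphenyl in place of 2-fluoro-6-methylphenyl on an aromatic carbon. Going by the values given here, one measured step bears on this, an exchange on the same aromatic carbon: a 6.8-fold lower number from compound 1 to compound 2 (0.83 log units; beyond the scatter), a modest step. Its direction says little about the new group, so only a small upward move from the low value of compound 2 is expected. The expected change is a 1.9-fold higher number from compound 2 to compound 3 (0.28 log units; within the scatter). Compound 3 is estimated at 0.14 h, with an expected range of 0.05 h to 0.45 h.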

Compound 3, half-life: 0.0583 h
Compound 3: the middle estimate sits 2.4-fold (0.38 log units) above what was measured; the measured number falls inside the stated range.
By their numbers in this assay, from the lowest: compounds 3 and 2 (each within the scatter of the next); then compound 1.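

In this assay, exchanging 2-fluoro-6-methylphenyl for 2-bromo-6-methoxyphenyl leaves the number within the scatter (a 1.3-fold lower number from compound 2 to compound 3 (0.10 log units; within the scatter)), so these two groups cannot be told apart at this position. Against 2,5-dimethylphenyl, the new group gives a drop beyond the scatter (an 8.6-fold lower number from compound 1 to compound 3 (0.93 log units; beyond the scatter)), so compound 2 and compound 3 both sit clearly under compound 1. No available evidence bears on the reason for either step.

Still open, as far as these compounds go, is how an unsubstituted phenyl would compare at this position. Also open, from the compounds shown here alone, is whether an amine or a carboxylic acid on this ring would shift the half-life.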